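The source may hold more compounds than are shown below. What is called first, only, known or untested is meant among the compounds shown, and "the series" means these compounds.

Compound 1 `O=C(NC1CCCCC1)NS(=O)(=O)N1CCC(CCNC(=O)c2cscn2)CC1` gives 23% in a functional assay on the whole organism (blood) with Rattus norvegicus as the target, with stated times of 24 h and 1 h, at a dose of 5 mg/kg by the intraperitoneal route; a lower number here means a weaker effect, a higher number a stronger effect of the compound at the dose given; compound 2 `COc1ccc2nccc(C(=O)NCCC3CCN(S(=O)(=O)NC(=O)NC4CCCCC4)CC3)c2c1` gives 15% in this assay.

Compound 2 stands at the lower of the two numbers, with compound 1 nearest; the step of a number 8 percentage points lower from compound 1 to compound 2 (within the scatter) is within the scatter. Compound 3 `O=C(NC1CCCCC1)NS(=O)(=O)N1CCC(CCNC(=O)c2cccc3cccnc23)CC1` differs from compound 2 by quinolin-8-yl in place of 6-methoxyquinolin-4-yl on a carbonyl carbon. Within the data shown here, the only step that bears on this change, a number 8 percentage points lower from compound 1 to compound 2 (within the scatter), exchanged the aryl group on the same carbonyl carbon and stayed within the scatter, so the expected step of a number 3 percentage points higher from compound 2 to compound 3 (within the scatter) is likewise none beyond the scatter. Compound 3 is therefore estimated at 18%, with a range from 5% to 35%.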

Compound 3, a percentage reported as activity, at one dose (the size of the read-out at that dose, not a potency): 37%
Compound 3: the middle estimate sits 19 percentage points below what was measured; measured number outside the range, above it.
By their numbers in this assay, from the lowest: compounds 2 and 1 (each within the scatter of the next); then compound 3.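

In this assay, the group on this carbonyl carbon proved able to move the read-out beyond the scatter, which the earlier exchange had not shown: quinolin-8-yl gave a number 22 percentage points higher from compound 2 to compound 3 (beyond the scatter) and a number 14 percentage points higher from compound 1 to compound 3 (beyond the scatter). The change from compound 2 to compound 3 alters both the attachment of the quinoline and the methoxy group, so these two differences cannot be separated. No measured evidence accounts for the gain. As far as these compounds go, it remains open whether a phenyl or pyridin-3-yl group on this carbonyl carbon would match compound 3.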